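Pyrazoline sulfonamides: aryl swap at the saturated carbon

The source may hold more compounds than are shown below. What is called first, only, known or untested is meant among the compounds shown, and "the series" means these compounds.

Measured so far:
compound 1 `Cc1cc(O)c(C2=NN(c3ccc(S(N)(=O)=O)cc3)C(c3ccccc3O)C2)cc1Cl`: 37600 nM
compound 2 `Cc1cc(O)c(C2=NN(c3ccc(S(N)(=O)=O)cc3)C(/C=C/c3ccccc3)C2)cc1Cl`: 37200 nM

In a functional assay on MDA-MB-468 cells (Homo sapiens) for antiproliferative activity, with a stated time of 48 h (a lower number here means that less compound is tolerated, a higher number that more compound is tolerated), compound 2 stands as the lowest of the two numbers, but its value and that of compound 1 lie within the scatter, so no order is read into them. Compound 3 `COc1ccc(C2CC(c3cc(Cl)c(C)cc3O)=NN2c2ccc(S(N)(=O)=O)cc2)cc1OC` differs from compound 2 in one place: 3,4-dimethoxyphenyl in place of 2-phenylethenyl on a saturated ring carbon. Among the measured compounds shown here, the only step that bears on this position is a 1.0-fold lower number from compound 1 to compound 2 (0.00 log units; within the scatter), which shows exchange of the group here to be without effect beyond the scatter. No change beyond the scatter is therefore expected in this assay; the step of a 1.0-fold lower number from compound 2 to compound 3 (0.00 log units; within the scatter) is the estimate. Compound 3 is expected at 37000 nM, within 18000 nM to 75000 nM.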

Compound 3, concentration lethal to 50% of the cells: > 100000 nM
Compound 3: only a limit was reported (the forecaster's own chance of this, stated with the estimate: 5%); middle value at least 2.7-fold (0.43 log units) from the limit.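

In this assay, the saturated ring carbon no longer looks indifferent to its group once 3,4-dimethoxyphenyl enters, which gives an at least 2.6-fold higher number from compound 2 to compound 3 (0.42 log units; beyond the scatter) and an at least 2.6-fold higher number from compound 1 to compound 3 (0.42 log units; beyond the scatter). The earlier exchange had stayed within the scatter. The value for compound 3 is a limit, not a number: the limit of > 100000 nM in this assay, at which 1 of the 3 values shown sits.

On these data alone, the actual number for compound 3 remains open, as does which of the two methoxy groups matters. Also open, as far as these compounds go, is what a carboxylic acid or an amine on the phenyl ring at this carbon would give.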